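This account rests on a few compounds, and the source may have more. Where it says the series, first, only, none or still open, it means among the compounds named here.

Compound 1 `CC(C)C(/C=C1\NC(=O)NC1=O)c1ccc(-c2ccc3cccc(F)c3c2)[nH]c1=O` gives 87 nM in a functional assay on CHO cells for antagonist activity at prostaglandin E2 receptor EP3 subtype (Homo sapiens), read by cAMP accumulation, with a stated time of 30 min; a higher number here means a weaker inhibitor, a lower number a stronger inhibitor. Compound 2 `CC(C)C(CC1C(=O)NC(=O)N1C)c1ccc(-c2ccc3cccc(F)c3c2)[nH]c1=O` gives 65 nM in this assay, and the step of a 1.3-fold lower number from compound 1 to compound 2 (0.13 log units; within the scatter) leaves the two numbers indistinguishable, so compound 2 simply has the lower of the two numbers shown. Compound 3 `CC(C)C(c1ccc(-c2ccc3cccc(F)c3c2)[nH]c1=O)C1NC(=O)NC1=O` carries 2,5-dioxoimidazolidin-4-yl in place of (3-methyl-2,5-dioxoimidazolidin-4-yl)methyl on a saturated chain carbon bound to an aromatic carbon and a saturated chain carbon. Among the measured compounds shown here, the only measured step at this same position, a 1.3-fold lower number from compound 1 to compound 2 (0.13 log units; within the scatter), stayed within the scatter, so no large shift is expected, though shortening the link adds uncertainty. Compound 3 is therefore estimated at 120 nM in this assay, within 40 nM to 400 nM, an expected step of a 1.8-fold higher number from compound 2 to compound 3 (0.27 log units; within the scatter).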

Compound 3, half-maximal inhibitory concentration: 320 nM
Estimate against measurement, compound 3: 2.7-fold (0.43 log units) below, and the stated range covers the measured number.
By their numbers in this assay, from the lowest: compounds 2 and 1 (each within the scatter of the next); then compound 3.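

Unlike the earlier pair, this change at the saturated chain carbon moves the number: the step of a 4.9-fold higher number from compound 2 to compound 3 (0.69 log units; beyond the scatter) lies beyond the scatter. Compound 1 also lacks the ring methyl, and the step of a 3.7-fold higher number from compound 1 to compound 3 (0.57 log units; beyond the scatter) is likewise beyond the scatter, so the shorter link goes with the higher number even without a change in that methyl. No measurement shown bears on the reason. From the compounds shown here alone, whether a longer chain carrying the same ring, or a carboxylic acid in place of that ring, would keep the lower number remains open.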